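A few compounds are considered here, and "the series" means these few. Any claim that something is new, unique, unknown or untested is made for them only; others in the source may bear on it.

Measured so far in an ADME assay on BJ cells (Homo sapiens), read by MTT assay, with a stated time of 3 days; on this read-out lower numbers stand for stronger inhibition and higher numbers for weaker inhibition:
- compound 1, `COc1ncnc2[nH]cc(Sc3cccs3)c12`: 123000 nM
- compound 2, `CN(C)c1ncnc2[nH]cc(Sc3cccs3)c12`: 145000 nM

Compound 1 gives the lowest of the two numbers seen in this assay; its nearest neighbour is compound 2, and the step of a 1.2-fold higher number from compound 1 to compound 2 (0.07 log units; within the scatter) is within the scatter, so the two cannot be told apart. The step from compound 1 to the not yet measured compound 3, `c1coc(-c2ncnc3[nH]cc(Sc4cccs4)c23)c1`, is furan-2-yl in place of methoxy on an aromatic carbon. Within the data shown here, the only measured step, from compound 1 to compound 2, concerns a different group at the same place, dimethylamino in place of methoxy, and it was within the scatter; it does not speak directly to the entry of furan-2-yl. Among the measured compounds shown here, with no step that bears on this change, any expectation rests on the two numbers alone, both of which are high. Compound 3 is therefore expected to give 80000 nM, in the range 25000 nM to 250000 nM, a step of a 1.5-fold lower number from compound 1 to compound 3 (0.19 log units; within the scatter) that may well stay within the scatter.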

Compound 3, half-maximal inhibitory concentration: 22100 nM
Estimate against measurement, compound 3: 3.6-fold (0.56 log units) above, and the stated range ends above it.
By their numbers in this assay, from the lowest: compound 3; then compounds 1 and 2 (each within the scatter of the next).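

Until now, methoxy and dimethylamino at this aromatic carbon could not be told apart in this assay, so the position gave no sign of responding to a change of group. Furan-2-yl shows that it can respond: replacing methoxy gives a 5.6-fold lower number from compound 1 to compound 3 (0.75 log units; beyond the scatter), and replacing dimethylamino gives a 6.6-fold lower number from compound 2 to compound 3 (0.82 log units; beyond the scatter). Of the three groups, furan-2-yl is the only one that brings a five-membered aromatic ring to this place, although nothing available accounts for the lower number.

The compounds shown leave open whether the lower number belongs to furan-2-yl alone or would also come with another aromatic ring here, such as phenyl or thiophen-2-yl. They also leave open how a non-aromatic ring such as morpholine would compare at the same carbon.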